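Swapping diethylamino for 4-chloropiperidin-1-yl on compound 2

The source may hold more compounds than are shown below. What is called first, only, known or untested is meant among the compounds shown, and "the series" means these compounds.

Going by the values given here, only two compounds have so far been examined in a functional assay on HepG2 cells (Homo sapiens) for cytotoxicity, read by MTT assay, with a stated time of 48 h (on this read-out higher numbers stand for weaker inhibition and lower numbers for stronger inhibition), and just one of them yields a number. Compound 1 (`CC1=NN(S(=O)(=O)c2ccc(C)cc2)C(c2cc(Br)cc(Br)c2O)C1`) is reported as "not active" (no number reported) without any figure. Among the compounds with values here, compound 2 (`CCN(CC)CC(=O)N1N=C(C)CC1c1ccccc1O`) gives 51600 nM in this assay and is thus the only measured value available, so it cannot be ranked against any other number.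

Compound 3 (`CC1=NN(C(=O)CN2CCC(Cl)CC2)C(c2ccccc2O)C1`) has 4-chloropiperidin-1-yl in place of diethylamino on a saturated chain carbon bound to a carbonyl carbon and otherwise matches compound 2. Within the data shown here, no measured pair shows what such an exchange does in this assay and the data therefore offer no firm direction. With compound 2 at 51600 nM as the sole anchor, a change no larger than the usual scatter is expected, with only a slight lean towards stronger inhibition. The expected step is a 1.5-fold lower number from compound 2 to compound 3 (0.17 log units; within the scatter) and this estimate stays within that scatter. The estimated value for compound 3 is 35000 nM within an expected range of 10000 nM to 100000 nM as matters stand.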

Compound 3, half-maximal inhibitory concentration: 42100 nM
For compound 3 the middle estimate is 1.2-fold (0.08 log units) below the measured one, and the stated range covers the measured number.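

In this assay, going by these compounds alone, putting 4-chloropiperidin-1-yl in place of diethylamino on a saturated chain carbon bound to a carbonyl carbon gives a 1.2-fold lower number from compound 2 to compound 3 (0.09 log units; within the scatter), and this is the only step at this position that can be read so far. Where compound 2 alone offered a single number with nothing to set it against, this pair shows that an open diethylamino group and a six-membered non-aromatic ring carrying chlorine can occupy this place with the two values remaining within the usual scatter of each other, so the read-out does not tell compound 2 and compound 3 apart. No measurement shown here offers an explanation for this outcome.

The compounds shown leave open what the chlorine contributes on its own, which a piperidin-1-yl group without it would help to separate from the effect of the ring. They also leave open whether a morpholin-4-yl group, a primary amine or a carboxylic acid at this same place would carry the number beyond the scatter in either direction.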